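Bromophenyl Triazole Ester Expected to Stay at Limit

This account rests on a few compounds, and the source may have more. Where it says the series, first, only, none or still open, it means among the compounds named here.

Compound 1, `C/C(=C\CC/C(C)=C/CC[C@@H]1[C@@]2(C)CCC(=O)C(C)(C)[C@H]2CC[C@@]1(C)O)CC/C=C(\C)C(=O)OCc1cn(-c2ccc([N+](=O)[O-])cc2)nn1`, is a triazole ester of a terpenoid core bearing a 4-nitrophenyl group on the ring nitrogen. In a functional assay on A549 cells (Homo sapiens) for antiproliferative activity, read by MTT assay, with a stated time of 48 h (on this read-out higher numbers stand for weaker inhibition and lower numbers for stronger inhibition), compound 1 gives only a limit, > 150000 nM, and not a number. Two relatives stand beside it. Compound 2, `C/C(=C\CC/C(C)=C/CC[C@@H]1[C@@]2(C)CCC(=O)C(C)(C)[C@H]2CC[C@@]1(C)O)CC/C=C(\C)C(=O)OCc1cn(-c2ccccc2[N+](=O)[O-])nn1`, has 2-nitrophenyl in place of 4-nitrophenyl on an aromatic nitrogen. In this assay compound 2 likewise stops at the limit, > 150000 nM. Compound 3, `C/C(=C\CC/C(C)=C/CC[C@@H]1[C@@]2(C)CCC(=O)C(C)(C)[C@H]2CC[C@@]1(C)O)CC/C=C(\C)C(=O)OCc1cn(-c2ccccc2Br)nn1`, has 2-bromophenyl in place of 4-nitrophenyl on an aromatic nitrogen. In this assay compound 3 also gives only the limit, > 150000 nM. Because every value shown sits at the limit of > 150000 nM in this assay, at which 3 of the 3 values shown sit, the steps a step that the two limits leave unreadable from compound 1 to compound 2, a step that the two limits leave unreadable from compound 1 to compound 3 and a step that the two limits leave unreadable from compound 2 to compound 3 cannot be read for size or direction. Compound 4, `C/C(=C\CC/C(C)=C/CC[C@@H]1[C@@]2(C)CCC(=O)C(C)(C)[C@H]2CC[C@@]1(C)O)CC/C=C(\C)C(=O)OCc1cn(-c2cccc(Br)c2)nn1`, is the compound still to be measured. It differs from compound 1 as follows: 3-bromophenyl in place of 4-nitrophenyl on an aromatic nitrogen. The measured steps that bear on it, the two swaps of the aryl group on the same aromatic nitrogen, leave nothing readable, so no step beyond the scatter can be expected in this assay, and the expected step is a step that the limit leaves unreadable from compound 1 to compound 4. Compound 4 is therefore estimated to give about 200000 nM, most likely again only as a limit, within 100000 nM to 500000 nM.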

Compound 4, half-maximal inhibitory concentration: > 150000 nM
Compound 4: only a limit was reported; the forecaster's own chance of this, stated with the estimate: 85%; the middle value does not contradict the limit.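

In this assay compound 4 gives only a limit, > 150000 nM. The steps from compound 1, compound 2 and compound 3 to compound 4 cannot be read for size or direction, because all four compounds stop at the same limit: the limit of > 150000 nM in this assay, at which 4 of the 4 values shown sit.

The compounds shown leave open whether any change of the aryl group on the aromatic nitrogen alters antiproliferative activity at all.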